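Replacing the Trimethoxyphenyl Arm of Compound 3

The source may hold more compounds than are shown below. What is called first, only, known or untested is meant among the compounds shown, and "the series" means these compounds.

Three compounds sharing one core were tested in a functional assay on SW-620 cells (Homo sapiens) for inhibition; a higher number here means a weaker inhibitor of growth, a lower number a stronger inhibitor of growth. Compound 1 `COc1cc(/C=C/C(=O)c2cccc(-n3cc(-c4ccc(Cl)cc4)[nH]c3=O)c2)ccc1O` gives 2000 nM, and compound 2 `COc1cc(/C=C/C(=O)c2cccc(-n3cc(-c4ccccc4)[nH]c3=O)c2)ccc1O` gives 2290 nM; the step of a 1.1-fold higher number from compound 1 to compound 2 (0.06 log units; within the scatter) is small. Compound 3 `COc1ccc(-c2cn(-c3cccc(C(=O)/C=C/c4cc(OC)c(OC)c(OC)c4)c3)c(=O)[nH]2)cc1` gives 450 nM, the lowest of the three numbers and beyond the scatter from both others. Compound 4 `COc1ccc(-c2cn(-c3cccc(C(=O)/C=C/c4ccc(O)c(OC)c4)c3)c(=O)[nH]2)cc1` differs from compound 3 in one place: 4-hydroxy-3-methoxyphenyl in place of 3,4,5-trimethoxyphenyl on a double-bonded chain carbon bound to a double-bonded chain carbon. Going by the values given here, no measured step shows this exact change; the only measured step, a 1.1-fold higher number from compound 1 to compound 2 (0.06 log units; within the scatter), alters a different ring. Still, compound 1 and compound 2 already carry the 4-hydroxy-3-methoxyphenyl group and sit well above compound 3, so weaker growth inhibition is expected, with a step of about a 3.3-fold higher number from compound 3 to compound 4 (0.52 log units; beyond the scatter). Compound 4 is therefore estimated at 1500 nM, within a range from 600 nM to 4000 nM.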

Compound 4, concentration for 50% growth inhibition: 2500 nM
For compound 4 the middle estimate is 1.7-fold (0.22 log units) below the measured one; the measured number falls inside the stated range.
By their numbers in this assay, from the lowest: compound 3; then compounds 1, 2 and 4 (each within the scatter of the next).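

The change from 3,4,5-trimethoxyphenyl to 4-hydroxy-3-methoxyphenyl now has a measured size at this position (a 5.6-fold higher number from compound 3 to compound 4 (0.74 log units; beyond the scatter)), so this arm clearly affects growth inhibition in compound 3. Once 4-hydroxy-3-methoxyphenyl is in place, changing the group on the other ring makes no clear difference, with methoxy for hydrogen (a 1.1-fold higher number from compound 2 to compound 4 (0.04 log units; within the scatter)) and methoxy for chloro (a 1.3-fold higher number from compound 1 to compound 4 (0.10 log units; within the scatter)) both small. Nothing available explains the effect of the arm. The change alters two things at once, so the hydroxy group and the lost methoxy group cannot be told apart. On these data alone, how 3,4-dimethoxyphenyl, or an arm carrying an amine or a carboxylic acid, would behave here remains open.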